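An Aryl Swap at the Assay Limit

The compounds below may be only part of what the source reports. "The series", "measured", "known", "first", "only" and "open" are said of these compounds alone.

In a functional assay on Jurkat cells (Homo sapiens) (on this read-out higher numbers stand for weaker inhibition and lower numbers for stronger inhibition), three close analogues give the same kind of result. Compound 1, `CC(C)[C@H](NC(=O)COc1cccc2ccccc12)C(=O)N[C@@H](CC(=O)O)C(=O)COc1cccc2ccccc12`, gives > 100000 nM, which is a limit of the assay and not a number. Compound 2, `CC(C)[C@H](NC(=O)COc1cccc2ccccc12)C(=O)N[C@@H](CC(=O)O)C(=O)COc1ccc2ccccc2c1`, gives > 100000 nM, again a limit. Compound 3, `CC(C)[C@H](NC(=O)COc1cccc2ccccc12)C(=O)N[C@@H](CC(=O)O)C(=O)COc1cc(C(F)(F)F)cc(C(F)(F)F)c1`, gives > 100000 nM, also a limit. Compound 2 therefore has no number of its own and stands at the limit of > 100000 nM in this assay, at which 3 of the 3 values shown sit.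

Compound 4, `CC(=O)Nc1cccc(OCC(=O)[C@H](CC(=O)O)NC(=O)[C@@H](NC(=O)COc2cccc3ccccc23)C(C)C)c1`, carries 3-acetamidophenyl in place of naphthalen-2-yl on an oxygen on a saturated carbon. Among the compounds with values here, the one measured step that bears on this change is a step that the two limits leave unreadable from compound 1 to compound 2, where naphthalen-2-yl replaces naphthalen-1-yl at the same place. Its size cannot be read, so it offers no basis for expecting a clear step in either direction in this assay. The expected change is a number no higher from compound 2 to compound 4 (the limit leaves the size open). The estimate for compound 4 is 100000 nM, with an expected range of 30000 nM to 300000 nM.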

Compound 4, half-maximal inhibitory concentration: > 100000 nM
Compound 4 was reported as a limit; the forecaster's own chance of this, stated with the estimate: 80%; the middle value lies on the limit itself.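

In this assay compound 4 gives > 100000 nM which is a limit of the assay and not a number. The steps to compound 4 from compound 1 and compound 2 therefore cannot be read. The compounds shown leave open how these aryl groups rank against one another.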